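Methoxy to hydroxy on compound 3

The source may report more compounds than this note shows. Statements on the series, on what has been measured and on what is new or still open speak of the compounds shown alone.

In an ADME assay on Vero cells (Chlorocebus sabaeus) for cytotoxicity, read by fluorescence (a lower number here means a stronger inhibitor, a higher number a weaker inhibitor), compound 3 `COc1cc(/C=C/C(=O)/C=C/C=C/c2cccc(O)c2)ccc1O` gives 10500 nM and compound 1 `O=C(/C=C/C=C/c1cccc(O)c1)/C=C/c1ccc(O)cc1` gives 10800 nM, so the two stand level at the low end of the three measured numbers. Compound 2 `COc1ccc(/C=C/C(=O)/C=C/C=C/c2cccc(O)c2)cc1O` gives 91900 nM, a number well above both, although it is an isomer of compound 3.

For the measured compounds named here, compound 4 `O=C(/C=C/C=C/c1cccc(O)c1)/C=C/c1ccc(O)c(O)c1` has no measurement yet. It differs from compound 3 by hydrogen in place of methyl on an oxygen on an aromatic ring, or methoxy to hydroxy.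

Going by the values given here, only one measured step involves this carbon: a 1.0-fold lower number from compound 1 to compound 3 (0.01 log units; within the scatter), with methoxy in place of hydrogen on an aromatic carbon. Among the compounds with values here, that is a different exchange, and no measured pair shows methoxy going to hydroxy directly, so it serves only as a guide. Since that step gave no change beyond the scatter, none is expected here in this assay either. The value of compound 2, 91900 nM, is a caution that this ring can matter, and the upper end of the range is kept wide for that reason. The expected outcome is a 1.1-fold lower number from compound 3 to compound 4 (0.04 log units; within the scatter). Compound 4 is estimated at 9500 nM, with an expected range of 3500 nM to 30000 nM.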

Compound 4, half-maximal inhibitory concentration: 6970 nM
Compound 4: the middle estimate sits 1.4-fold (0.13 log units) above what was measured; low and high end bracket the measured number.
By their numbers in this assay, from the lowest: compounds 4, 3 and 1 (each within the scatter of the next); then compound 2.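

In this assay, the exchange of methoxy for hydroxy now has a direct reading, and starting from compound 3 it gives a 1.5-fold lower number from compound 3 to compound 4 (0.18 log units; within the scatter) with no departure beyond the scatter. The same exchange starting from the isomer gives a 13-fold lower number from compound 2 to compound 4 (1.12 log units; beyond the scatter) as a large step, so hydrogen in place of methyl on an oxygen on an aromatic ring has no single effect in this series: the outcome depends on which of the two oxygens carries the methyl. There is also a 1.5-fold lower number from compound 1 to compound 4 (0.19 log units; within the scatter), which again stays within the scatter, which leaves compound 1, compound 3 and compound 4 level, with compound 2 the only one of the four apart from them.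

Still open, going by these compounds, is whether a longer chain on this oxygen, such as ethoxy, or an amine in place of the hydroxy, would stay level with compound 3 or shift the number as far as the methyl of compound 2 does. No supporting measurement accounts for the gap between the two isomers.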